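The source may hold more compounds than are shown below. What is called first, only, known or untested is meant among the compounds shown, and "the series" means these compounds.

Working notes on the sulfonamide series.

Compound 1 `O=S(=O)(Nc1ccc2oc(-c3ccccc3)nc2c1)c1cccc(C(F)(F)F)c1` is measured in an assay on isolated protein for inhibition of malate dehydrogenase, mitochondrial (Sus scrofa), with stated times of 45 min and 30 min; on this read-out lower numbers stand for stronger inhibition and higher numbers for weaker inhibition. Compound 1 gives > 63000 nM, which is a limit of the assay and not a number. Compound 2 `O=S(=O)(Nc1ccc2oc(-c3ccccc3)nc2c1)c1cccc(F)c1` differs from compound 1 by a fluoro in place of trifluoromethyl on an aromatic carbon. Compound 2 gives > 63000 nM in this assay, again a limit rather than a number. The step that the two limits leave unreadable from compound 1 to compound 2 therefore cannot be read in size or direction. Compound 3 `O=S(=O)(Nc1ccc(-c2nc3ccccc3o2)cc1)c1cccc(F)c1` carries the same sulfonyl aryl as compound 2 on a different arrangement of the shared core. Compound 3 gives > 63000 nM, also a limit. Where compound 2 stands is thus only a limit; the evidence the limit of > 63000 nM in this assay, at which 3 of the 3 values shown sit, shows the whole measured set sitting at that same limit.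

Compound 4 `COc1ccc(Cl)cc1S(=O)(=O)Nc1ccc2oc(-c3ccccc3)nc2c1` is not yet measured. The change from compound 2 is 5-chloro-2-methoxyphenyl in place of 3-fluorophenyl on a sulfonyl sulfur. Among the compounds with values here, no measured step bears on an exchange at the sulfonyl sulfur, and the one measured step that touches the sulfonyl aryl is unreadable between two limits, so no direction can be drawn from it. The expectation for compound 4 is therefore that the value stays near the limit in this assay, with the step of an at least 1.2-fold lower number from compound 2 to compound 4 (0.10 log units; that floor lies within the scatter) expected to be unreadable. Compound 4 is estimated at 50000 nM, within 8000 nM to 120000 nM.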

Compound 4, half-maximal inhibitory concentration: > 63000 nM
Compound 4: a limit, no number (the forecaster's own chance of this, stated with the estimate: 70%); middle value at least 1.2-fold (0.10 log units) from the limit.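

In this assay compound 4 gives > 63000 nM, a limit and not a number. Compound 2 also stands at a limit, and the step between compound 2 and compound 4 cannot be read. The compounds shown leave open whether any change on the sulfonyl aryl or the shared core gives a readable number: the limit of > 63000 nM in this assay, at which 4 of the 4 values shown sit.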